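Stilbene series: fluoro to chloro swap on a pyridyl core

The source may hold more compounds than are shown below. What is called first, only, known or untested is meant among the compounds shown, and "the series" means these compounds.

Measured so far:
Compound 1 `CN(C)c1ccc(/C=C/c2c(F)cccc2Cl)cc1`: 19.2 nM
Compound 2 `CN(C)c1ccc(/C=C/c2c(Cl)cccc2Cl)cc1`: 214 nM
Compound 3 `CN(C)c1ccc(/C=C/c2c(F)cccc2Cl)cn1`: 4.7 nM

Numbers come from a functional assay on LS174T cells (Homo sapiens) for antiproliferative activity; on this read-out higher numbers stand for weaker inhibition and lower numbers for stronger inhibition. Compound 1 and compound 2 share one core and differ by chloro in place of fluoro on an aromatic carbon; the step is an 11-fold higher number from compound 1 to compound 2 (1.05 log units; beyond the scatter). Compound 3 carries a different core; how the core of compound 3 differs from that of compound 1 is not broken down here. In this assay compound 3 gives the lowest number of the three, with compound 1 nearest and compound 2 furthest.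

Compound 4 `CN(C)c1ccc(/C=C/c2c(Cl)cccc2Cl)cn1` is not yet measured. It differs from compound 3 by chloro in place of fluoro on an aromatic carbon, the same change as from compound 1 to compound 2, since the place descriptions match word for word.

Among the measured compounds shown here, the expectation for compound 4 rests on the one measured instance of this change: the step from compound 3 to compound 4 is expected to be an 11-fold higher number from compound 3 to compound 4 (1.03 log units; beyond the scatter), close to an 11-fold higher number from compound 1 to compound 2 (1.05 log units; beyond the scatter). For the measured compounds named here, compound 4 is therefore estimated at 50 nM in this assay, with a range from 15 nM to 160 nM, the range being wide because only one prior step, an 11-fold higher number from compound 1 to compound 2 (1.05 log units; beyond the scatter), carries the expectation.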

Compound 4, half-maximal inhibitory concentration: 30.1 nM
Compound 4: middle estimate off by 1.7-fold (0.22 log units), on the high side, and the stated range covers the measured number.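

In this assay, chloro in place of fluoro gives a higher number on the second core as well, a 6.4-fold higher number from compound 3 to compound 4 (0.81 log units; beyond the scatter), so the direction seen on the core of compound 1 carries over to the core of compound 3. The two steps do not separate in size: the same change on two cores in this assay, an 11-fold higher number (1.05 log units; beyond the scatter) from compound 1 to compound 2 and a 6.4-fold higher number (0.81 log units; beyond the scatter) from compound 3 to compound 4, 1.7-fold (0.24 log units) apart, within the scatter of two such steps. Among the compounds shown here, this shows that the change carries across these two cores, but with only two pairs in a single cell read-out it does not show that the change would carry to any further core, and it gives no reason for the step.

Still open, from the compounds shown here alone, is whether a bromo, methyl or nitrile group on the same aromatic carbon would fall in line with fluoro or with chloro. Also open, going by these compounds, is whether the step keeps its size when the dimethylamino group, common to all four compounds, gives way to a diethylamino group or another amine.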